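The compounds below may be only part of what the source reports. "The series", "measured", "known", "first", "only" and "open" are said of these compounds alone.

Of the compounds shown here, two of this set have been measured in an assay on membranes from CHO cells for displacement of a labelled ligand from adenosine receptor A1 (Homo sapiens), read by scintillation counting, with a stated time of 60 min, tested at 1 uM; on this read-out higher numbers stand for more inhibition at the one concentration tested (going by the name of the read-out) and lower numbers for less inhibition. Compound 1, `CC(=O)C1=C(C)NC(=O)NC1c1ccsc1`, gives 9% in this assay. Compound 2, `CC1=C(C(=O)NC(C)C)C(c2cccs2)NC(=O)N1`, gives 2% in this assay. For the measured compounds named here, compound 2 carries the smaller of the two numbers so far, but the number of compound 1 lies within the usual scatter of it, so no real difference between the two can be claimed. Compound 3, `CC1=C(C(=O)NC(C)C)C(c2ccsc2)NC(=O)N1`, has not yet been measured. It differs from compound 2 in one place: thiophen-3-yl in place of thiophen-2-yl on a saturated ring carbon. Going by the values given here, no step between measured compounds isolates this change, since compound 1 and compound 2 differ in more than one place. Given that both numbers so far sit low and close together, the step of a number 3 percentage points higher from compound 2 to compound 3 (within the scatter) is expected to stay within the scatter. Compound 3 is therefore estimated to give 5% in this assay, between -5% and 15%.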

Compound 3, a percentage reported as inhibition, at one concentration (the size of the read-out at that concentration, not a potency): 8%
Estimate against measurement, compound 3: 3 percentage points below, within the range that was stated.
By their numbers in this assay, from the lowest: compounds 2, 3 and 1 (each within the scatter of the next).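

In this assay, thiophen-3-yl in place of thiophen-2-yl on the saturated ring carbon gives a number 6 percentage points higher from compound 2 to compound 3 (within the scatter), so this position does not distinguish the two attachments of the thiophene at the one concentration tested. For the compounds shown here, the first single-place comparison on the carbonyl carbon, isopropylamino in place of methyl, gives a number 1 percentage points lower from compound 1 to compound 3 (within the scatter), and this change likewise shows no real difference. Nothing at hand bears on why these steps are small.

The compounds shown leave open whether a phenyl group on the saturated ring carbon, or a carboxylic acid or a longer amine chain on the carbonyl carbon, would move the number beyond the scatter. On these data alone, since each compound was read at a single concentration, their potencies also remain open.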